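Aryl swap on the ring nitrogen: compound 3

The source may hold more compounds than are shown below. What is called first, only, known or untested is meant among the compounds shown, and "the series" means these compounds.

Compound 2 `COc1cc2c(Oc3ccc(NC(=O)c4cn(-c5cc(C)ccc5C)cn4)cc3F)ccnc2cc1OCCCN1CCN(C)CC1` gives the higher of the two numbers measured in a functional assay on A549 cells (Homo sapiens) for cytotoxicity, read by MTT assay, with a stated time of 72 h (a higher number here means a weaker inhibitor, a lower number a stronger inhibitor), with 350 nM; compound 1 `COc1cc2c(Oc3ccc(NC(=O)c4cn(-c5ccccc5OC)cn4)cc3F)ccnc2cc1OCCCN1CCN(C)CC1` gives 70 nM in this assay. Going by the values given here, the one step measured so far, a 5.0-fold higher number from compound 1 to compound 2 (0.70 log units; beyond the scatter), shows that the aryl group on the ring nitrogen moves this assay by that much. Compound 3 `COc1cc2c(Oc3ccc(NC(=O)c4cn(-c5ccc(Cl)cc5)cn4)cc3F)ccnc2cc1OCCCN1CCN(C)CC1` carries a further change at the same place: 4-chlorophenyl in place of 2,5-dimethylphenyl on an aromatic nitrogen. Among the compounds with values here, no measured step covers a 4-chlorophenyl here, so the step from compound 2 can only be bounded by the spread seen between compound 1 and compound 2. Compound 3 is expected to land between those two, with the step of a 2.3-fold lower number from compound 2 to compound 3 (0.37 log units; beyond the scatter) taken as the estimate. The estimate for compound 3 in this assay is 150 nM, with a range from 40 nM to 600 nM.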

Compound 3, half-maximal inhibitory concentration: 5200 nM
For compound 3 the middle estimate is 35-fold (1.54 log units) below the measured one; the whole stated range lies below it.
By their numbers in this assay, from the lowest: compound 1; then compound 2; then compound 3.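

Working notes: at this position, on an aromatic nitrogen of the five-membered ring, the choice of aryl group can shift this assay far more than the modest first step suggested, with a 15-fold higher number from compound 2 to compound 3 (1.17 log units; beyond the scatter) and, across the full set, a 74-fold higher number from compound 1 to compound 3 (1.87 log units; beyond the scatter). Compound 3 is the weakest of the three, and its steps to both other compounds are beyond the scatter. The 2,5-dimethylphenyl and 4-chlorophenyl groups match in hydrogen-bond donors, hydrogen-bond acceptors, net charge and aromatic ring count, so none of these counts separates them, and no supporting data explain the loss.

Going by these compounds, it remains open whether the loss follows the chlorine itself or where it sits on the phenyl ring. A 2-chlorophenyl and an unsubstituted phenyl would address those two readings.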